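A few compounds are considered here, and "the series" means these few. Any claim that something is new, unique, unknown or untested is made for them only; others in the source may bear on it.

- Compound 1 `CCCN(CCC)C(=O)c1cncc(C(=O)N[C@@H](CC(=O)O)C(=O)CSCc2ccc(F)cc2)c1`: > 100000 nM, a limit of the assay
- Compound 2 `CN(C)S(=O)(=O)c1cncc(C(=O)N[C@@H](CC(=O)O)C(=O)CSCc2ccc(F)cc2)c1`: 21000 nM
- Compound 3 `CN(C1CC1)S(=O)(=O)c1cncc(C(=O)N[C@@H](CC(=O)O)C(=O)CSCc2ccc(F)cc2)c1`: 22000 nM
- Compound 4 `O=C(O)C[C@H](NC(=O)c1cncc(S(=O)(=O)NCc2ccccc2)c1)C(=O)CSCc1ccc(F)cc1`: not yet measured

In a functional assay on NT2 cells (Homo sapiens) for inhibition (on this read-out higher numbers stand for weaker inhibition and lower numbers for stronger inhibition), compound 3 gives 22000 nM. It stands level with compound 2, with a 1.0-fold higher number from compound 2 to compound 3 (0.02 log units; within the scatter). Compound 1 has only a limit, (the limit of > 100000 nM in this assay, at which 1 of the 3 values shown sits). Replacing its dipropylcarbamoyl group gave an at least 4.7-fold lower number from compound 1 to compound 2 (0.67 log units; beyond the scatter) and an at least 4.5-fold lower number from compound 1 to compound 3 (0.65 log units; beyond the scatter), but those steps exchange a whole group.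

Compound 4 keeps the sulfonyl sulfur and carries benzylamino in place of cyclopropyl(methyl)amino on a sulfonyl sulfur. The nearest measured change is a 1.0-fold higher number from compound 2 to compound 3 (0.02 log units; within the scatter), which stayed within the scatter. Among the measured compounds shown here, no measured step adds an aromatic ring or a hydrogen-bond donor here, so the expectation is loose: no step beyond the scatter in this assay. The expected step is a 1.2-fold lower number from compound 3 to compound 4 (0.09 log units; within the scatter). Compound 4 is estimated at 18000 nM, with an expected range of 6000 nM to 60000 nM.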

Compound 4, half-maximal inhibitory concentration: 59000 nM
Estimate against measurement, compound 4: 3.3-fold (0.52 log units) below; measured number inside the range.
By their numbers in this assay, from the lowest: compounds 2 and 3 (each within the scatter of the next); then compound 4. At a limit, above all of these: compound 1.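

In this assay, the group on the sulfonyl sulfur can shift the read-out after all: benzylamino gives a 2.7-fold higher number from compound 3 to compound 4 (0.43 log units; beyond the scatter) and a 2.8-fold higher number from compound 2 to compound 4 (0.45 log units; beyond the scatter), so weaker inhibition follows this change. The change brings in an aromatic ring and a hydrogen-bond donor together, and the compounds cannot separate the two. The step of an at least 1.6-fold lower number from compound 1 to compound 4 (0.22 log units; that floor lies within the scatter) does not set compound 4 clearly apart from compound 1, whose value is a limit: the limit of > 100000 nM in this assay, at which 1 of the 4 values shown sits.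

Which entering feature counts remains open. Methylamino and benzyl(methyl)amino on the same sulfur would pull the two apart.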